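Replacing phenoxy with an anilino group in cyanoguanidine vasorelaxants

The source may report more compounds than this note shows. Statements on the series, on what has been measured and on what is new or still open speak of the compounds shown alone.

Measured so far:
compound 1 `CC1(C)Oc2ccc(C#N)cc2[C@@H](/N=C(\NC#N)Oc2ccccc2)[C@@H]1O`, > 100000 nM
compound 2 `CC1(C)Oc2ccc(C#N)cc2[C@@H](/N=C(\NC#N)Nc2ccc(C(F)(F)F)cc2)[C@@H]1O`, 8100 nM
compound 3 `CSc1ccc(N/C(=N/[C@@H]2c3cc(C#N)ccc3OC(C)(C)[C@H]2O)NC#N)cc1`, 6300 nM

In a functional assay (aorta) with Rattus norvegicus as the target (a higher number here means a weaker inhibitor, a lower number a stronger inhibitor), compound 1 gives only a limit, > 100000 nM, and no number; it sits at the limit of > 100000 nM in this assay, at which 1 of the 3 values shown sits. Compound 4 `CC1(C)Oc2ccc(C#N)cc2[C@@H](/N=C(\NC#N)Nc2ccc(Cl)c(Cl)c2)[C@@H]1O` carries (3,4-dichlorophenyl)amino in place of phenoxy on a carbon with a double bond to nitrogen. Going by the values given here, the one measured step of the same kind, an at least 15-fold lower number from compound 1 to compound 3 (1.20 log units; beyond the scatter), is large, and the step of a 1.3-fold lower number from compound 2 to compound 3 (0.11 log units; within the scatter) shows that exchanging the group on the anilino ring of compound 2 for that of compound 3 leaves the read-out within the scatter. A step of similar size to that from compound 1 to compound 3 is therefore expected, toward a lower number: an at least 16-fold lower number from compound 1 to compound 4 (1.22 log units; beyond the scatter). Compound 4 is estimated to give 6000 nM in this assay, between 2000 nM and 20000 nM.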

Compound 4, half-maximal inhibitory concentration: 4600 nM
Compound 4: the middle estimate sits 1.3-fold (0.12 log units) above what was measured; measured number inside the range.
By their numbers in this assay, from the lowest: compounds 4, 3 and 2 (each within the scatter of the next). At a limit, above all of these: compound 1.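

With a second anilino compound in hand, the large step (an at least 21-fold lower number from compound 1 to compound 4 (1.33 log units; beyond the scatter)) shows that the gain from replacing phenoxy on this carbon is not tied to one ring substitution. The three anilino compounds are not separated by their ring substituents (a 1.4-fold lower number from compound 3 to compound 4 (0.14 log units; within the scatter); a 1.8-fold lower number from compound 2 to compound 4 (0.25 log units; within the scatter)), as both steps lie within the scatter. The value of compound 1 is only a limit, so the large step gives a bound and not a size: the limit of > 100000 nM in this assay, at which 1 of the 4 values shown sits.

Going by these compounds, whether an unsubstituted phenylamino group would give the same step remains open. So does the outcome with a chloro-substituted phenoxy group or an alkyl amine such as cyclohexylamino at this carbon.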